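This account rests on a few compounds, and the source may have more. Where it says the series, first, only, none or still open, it means among the compounds named here.

Notes on a short sulfonamide series in a functional assay on WiDr cells (Homo sapiens) for antiproliferative activity, read by sulforhodamine B assay, with a stated time of 48 h; a higher number here means a weaker inhibitor of growth, a lower number a stronger inhibitor of growth.

Compound 1 is `Cc1ccc(S(=O)(=O)N2CCC(Br)CC2)cc1`. In this assay compound 1 gives > 100000 nM, which is a limit of the assay and not a number. Compound 2 is `Cc1ccc(S(=O)(=O)N2CC[C@@H](Br)C[C@@H]2CC(C)C)cc1`. In this assay compound 2 gives 14000 nM. The step between them, an at least 7.1-fold lower number from compound 1 to compound 2 (0.85 log units; beyond the scatter), follows the change (isobutyl in place of hydrogen on a saturated ring carbon). The reading for compound 1 sits at the limit of > 100000 nM in this assay, at which 2 of the 3 values shown sit, so the size of that step is known only as a lower bound.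

Compound 3 is `Cc1ccc(S(=O)(=O)N2CC=C(Cl)CC2)cc1`. In this assay compound 3 gives > 100000 nM, again a limit of the assay. The difference between the core of compound 3 and the core of compound 1 is not broken down here.

Compound 4 is `Cc1ccc(S(=O)(=O)N2CCC(Cl)=CC2CC(C)C)cc1` and awaits measurement. It differs from compound 3 by isobutyl in place of hydrogen on a saturated ring carbon. This is the same kind of change as that from compound 1 to compound 2; the surroundings differ in that the place is two ring bonds from the ring atom that bears a chloro group rather than a bromo group.

The expected step of an at least 5.0-fold lower number from compound 3 to compound 4 (0.69 log units; beyond the scatter) is set beside an at least 7.1-fold lower number from compound 1 to compound 2 (0.85 log units; beyond the scatter), since compound 3 starts from the same limit as compound 1. Compound 4 is therefore expected near 20000 nM, within 5000 nM to 90000 nM.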

Compound 4, concentration for 50% growth inhibition: 21000 nM
For compound 4 the middle estimate is 1.1-fold (0.02 log units) below the measured one; measured number inside the range.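

In this assay, isobutyl in place of hydrogen on a saturated ring carbon gives an at least 4.7-fold lower number from compound 3 to compound 4 (0.67 log units; beyond the scatter), so on the core of compound 3 the change again lowers the number by more than the scatter. Set beside the earlier step, the same change reads as follows on the two cores: the same change on two cores in this assay, an at least 7.1-fold lower number (0.85 log units; beyond the scatter) from compound 1 to compound 2 and an at least 4.7-fold lower number (0.67 log units; beyond the scatter) from compound 3 to compound 4; the limit leaves it open whether they differ. The direction therefore holds on both cores, but neither step has a known size, and the parent compounds on which both steps start stand at a limit of the assay, not at a number: the limit of > 100000 nM in this assay, at which 2 of the 4 values shown sit.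

Open is whether a longer chain, an amine or a carboxylic acid at this place would give a step of like size, since isobutyl is the only group shown there. Among these compounds, also open is what the chloro and bromo groups add apart from the rest of the core, as compound 2 and compound 4 differ in more than one place and no step joins them.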